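The compounds below may be only part of what the source reports. "The series", "measured", "known", "first", "only" and "open" are said of these compounds alone.

Measured compounds:
compound 1 `CN1CCN(Cc2ccc(NC(=O)c3ccc(OCCCCl)c(N)c3)cc2C(F)(F)F)CC1`, 12900 nM
compound 2 `CN(C)C1CCN(Cc2ccc(NC(=O)c3ccc(OCCCCl)c([N+](=O)[O-])c3)cc2C(F)(F)F)C1`, 5800 nM

Of the compounds shown here, two have been tested in a toxicity assay on Huh-7.5 cells (Homo sapiens) for inhibition, read by MTT assay, with a stated time of 96 h; a higher number here means that more compound is tolerated, a lower number that less compound is tolerated. Compound 1 gives 12900 nM, while compound 2 gives 5800 nM. Of these two numbers, compound 2 has the lower one, so less of it is tolerated by the cells; the gap to compound 1 lies beyond the usual scatter. Compound 3 `CN(C)C1CN(Cc2ccc(NC(=O)c3ccc(OCCCCl)c([N+](=O)[O-])c3)cc2C(F)(F)F)C1` has not yet been measured. It differs from compound 2 in one place: 3-(dimethylamino)azetidin-1-yl in place of 3-(dimethylamino)pyrrolidin-1-yl on a saturated chain carbon bound to an aromatic carbon. The five-membered non-aromatic ring becomes a four-membered one, with one heavy atom fewer and the same count of hydrogen-bond acceptors. Among the measured compounds shown here, no step between two measured compounds shows what such a ring change does here. With no such guide, the step from compound 2 to compound 3 is expected to be small, a 1.0-fold higher number from compound 2 to compound 3 (0.01 log units; within the scatter), in no clear direction and within the scatter. Compound 3 is therefore estimated at 6000 nM, with a range from 2500 nM to 14000 nM.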

Compound 3, half-maximal cytotoxic concentration: 7800 nM
Compound 3: middle estimate off by 1.3-fold (0.11 log units), on the low side; the measured number falls inside the stated range.
By their numbers in this assay, from the lowest: compounds 2, 3 and 1 (each within the scatter of the next, the first and the last beyond it).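

At the saturated chain carbon bound to an aromatic carbon, 3-(dimethylamino)azetidin-1-yl in place of 3-(dimethylamino)pyrrolidin-1-yl gives a 1.3-fold higher number from compound 2 to compound 3 (0.13 log units; within the scatter) in this assay, the first single-place comparison available here. Shrinking this five-membered non-aromatic ring to a four-membered one therefore produces no difference that this assay can separate from the scatter of repeated measurements. The data offer no measurement that would explain this reading.

Going by these compounds, whether the same holds for a larger ring, such as 4-(dimethylamino)piperidin-1-yl, or for an open-chain group, such as dimethylaminomethyl, remains open. On these data alone, compound 1 differs from compound 2 and compound 3 in more than one place, so its steps to them cannot be read, and the separate contribution of its 4-methylpiperazin-1-yl group stays unknown.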